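A few compounds are considered here, and "the series" means these few. Any claim that something is new, unique, unknown or untested is made for them only; others in the source may bear on it.

Measured so far:
Compound 1, `CN(C[C@H]1Cc2c(cccc2N2CCN(C3CC3)CC2)CN1)[C@H]1CCCc2cccnc21`, 265 nm/s.
Compound 2, `CC(C)N(C[C@H]1Cc2c(cccc2N2CCNCC2)CN1)[C@H]1CCCc2cccnc21`, 16 nm/s.

For the measured compounds named here, in an ADME assay for permeability, using PAMPA, at pH 7.4 (a lower number here means that the compound crosses the layer more slowly, a higher number that the compound crosses the layer faster), compound 1 stands highest of the two numbers; compound 2 is its only neighbour, and the gap between them is well beyond the scatter. Compound 3, `CN(C[C@H]1Cc2c(cccc2N2CCN3CCC[C@H]3C2)CN1)[C@H]1CCCc2cccnc21`, has not been measured in this assay. It differs from compound 1 in one place: a group of 9 heavy atoms (7 carbon, 2 nitrogen; one five-membered non-aromatic ring with 1 hetero atom, one six-membered non-aromatic ring with 2 hetero atoms) in place of a group of 9 heavy atoms (7 carbon, 2 nitrogen; one three-membered non-aromatic ring of carbon only, one six-membered non-aromatic ring with 2 hetero atoms), on an aromatic carbon. The two compounds hold the same atoms, joined differently, and both keep the tertiary amine on that ring system. Going by the values given here, no step between two measured compounds matches this change, so the expectation rests on the number of compound 1 alone. A step of about the usual scatter, or none beyond it, is expected here. The step is estimated as a 1.3-fold lower number from compound 1 to compound 3 (0.12 log units; within the scatter). Compound 3 is estimated at 200 nm/s in this assay, with a range from 80 nm/s to 450 nm/s.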

Compound 3, apparent permeability: 167 nm/s
Compound 3: middle estimate off by 1.2-fold (0.08 log units), on the high side; measured number inside the range.
By their numbers in this assay, from the lowest: compound 2; then compounds 3 and 1 (each within the scatter of the next).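

The two earlier compounds differ in more than one place, so they gave no reading of this aromatic carbon alone, and compound 3 supplies the first. In this assay putting a group with a five-membered non-aromatic ring with 1 hetero atom and a six-membered non-aromatic ring with 2 hetero atoms in place of 4-cyclopropylpiperazin-1-yl, the same atoms joined differently, gives a 1.6-fold lower number from compound 1 to compound 3 (0.20 log units; within the scatter) and so stays within the scatter at this position. Nothing at hand accounts for this result.

On these data alone, whether a group of another kind at this aromatic carbon, such as morpholin-4-yl or a carboxylic acid, would also stay within the scatter remains open. Also open, as far as these compounds go, is how the opposite configuration at the defined stereocentre of the entering group would read.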